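This account rests on a few compounds, and the source may have more. Where it says the series, first, only, none or still open, it means among the compounds named here.

The measured compounds:
compound 1 `CC(=O)O[C@H]1C[C@@H](C)C=C2C=C[C@H](C)[C@H](CC[C@@H]3C[C@@H](O)CC(=O)O3)C21` gives 269 nM in an assay for inhibition of 3-hydroxy-3-methylglutaryl-coenzyme A reductase (Rattus norvegicus); a higher number here means a weaker inhibitor, a lower number a stronger inhibitor
compound 2 `CC(C)CC(=O)O[C@H]1C[C@@H](C)C=C2C=C[C@H](C)[C@H](CC[C@@H]3C[C@@H](O)CC(=O)O3)C21` gives 5.4 nM in this assay
compound 3 `CCC(C)(CC)C(=O)O[C@H]1C[C@@H](C)C=C2C=C[C@H](C)[C@H](CC[C@@H]3C[C@@H](O)CC(=O)O3)C21` gives 1.4 nM in this assay

Compound 3 stands lowest of the three numbers in this assay. Its nearest neighbour is compound 2, separated by a 3.9-fold lower number from compound 2 to compound 3 (0.59 log units; beyond the scatter), and its furthest is compound 1, separated by a 190-fold lower number from compound 1 to compound 3 (2.28 log units; beyond the scatter).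

Compound 4 `C[C@H]1C=C2C=C[C@H](C)[C@H](CC[C@@H]3C[C@@H](O)CC(=O)O3)C2[C@@H](OC(=O)Oc2ccccc2)C1` differs from compound 3 in one place: phenoxy in place of 1-ethyl-1-methylpropyl on a carbonyl carbon. Three measured steps change the group on the carbonyl carbon and bear on this change: a 50-fold lower number from compound 1 to compound 2 (1.70 log units; beyond the scatter), a 190-fold lower number from compound 1 to compound 3 (2.28 log units; beyond the scatter) and a 3.9-fold lower number from compound 2 to compound 3 (0.59 log units; beyond the scatter). In each of them the group on the carbonyl carbon grew from methyl to isobutyl or to 1-ethyl-1-methylpropyl and the number fell. Phenoxy brings a ring and an oxygen that none of the measured groups carries, so no step speaks to it directly. The change removes the 1-ethyl-1-methylpropyl group that accompanied the lowest number, and compound 4 is therefore expected to give a higher number than compound 3, an expected step of a 3.6-fold higher number from compound 3 to compound 4 (0.55 log units; beyond the scatter). Compound 4 is estimated at 5 nM, with a range from 1.5 nM to 20 nM.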

Compound 4, half-maximal inhibitory concentration: 83 nM
Compound 4: the middle estimate sits 17-fold (1.22 log units) below what was measured; the whole stated range lies below it.
By their numbers in this assay, from the lowest: compound 3; then compound 2; then compound 4; then compound 1.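

Among the compounds shown here, on this carbonyl carbon, the earlier compounds tied a larger carbon group to a lower number in this assay, and phenoxy goes against that link: although it enters with more heavy atoms than the 1-ethyl-1-methylpropyl it replaces, it gives a 59-fold higher number from compound 3 to compound 4 (1.77 log units; beyond the scatter) and, against isobutyl, a 15-fold higher number from compound 2 to compound 4 (1.19 log units; beyond the scatter) as well. The count of heavy atoms in the group therefore does not set the number by itself at this position, although phenoxy still keeps an advantage over methyl (a 3.2-fold lower number from compound 1 to compound 4 (0.51 log units; beyond the scatter)), so the group is not simply lost to the assay. Nothing given here bears on why phenoxy behaves this way.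

The compounds shown do not separate the ring from the oxygen, since phenoxy brings both at once: a benzyl group would keep the ring and drop that oxygen, and a cyclohexyloxy group would keep the oxygen without the aromatic ring. They also leave open whether a chlorine or a methoxy group on the phenyl ring, or a tert-butoxy group in place of phenoxy, would move the number back towards that of the branched carbon group.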